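The source may hold more compounds than are shown below. What is called first, only, known or untested is meant among the compounds shown, and "the series" means these compounds.

Compound 1 `CC(C)OCC1=CS(=O)(=O)c2ccccc2C1=O`: 99.2%
Compound 2 `O=C(OCC1=CS(=O)(=O)c2ccccc2C1=O)c1ccccc1`: 0%

Of the compounds shown here, two sharing one core have been measured so far. In a functional assay on the whole organism for inhibition, with Mus musculus as the target, at a dose of 10 mg/kg (on this read-out higher numbers stand for more inhibition at the one dose given (going by the name of the read-out) and lower numbers for less inhibition), compound 1 gives 99.2%, the higher of the two numbers. Among the measured compounds shown here, its closest companion, compound 2, gives 0% in this assay, a gap that lies well beyond the usual scatter of repeated runs; no single-change step between the two has been worked out, so only the two values themselves can be compared.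

Compound 3 `O=C1C(CNc2ccccc2)=CS(=O)(=O)c2ccccc21` has not yet been measured. It differs from compound 1 in one place: anilino in place of isopropoxy on a saturated chain carbon bound to a double-bonded ring carbon. The isopropoxy group of compound 1 is a short saturated chain, while the anilino group of compound 3 brings in an aromatic ring, as the benzoate of compound 2 does. With only two reference points, one very high and one at zero, the direction of the change is uncertain, and a step downward of moderate to large size seems the more likely outcome, with a broad range expected. The step expected from compound 1 to compound 3 is a number 54.2 percentage points lower from compound 1 to compound 3 (beyond the scatter). Compound 3 is estimated to give 45% in this assay, within a range from 5% to 90%.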

Compound 3, a percentage reported as inhibition, in the whole organism at one dose (the size of the read-out at that dose, not a potency): 0%
Compound 3: the middle estimate sits 45 percentage points above what was measured; the whole stated range lies above it.
By their numbers in this assay, from the lowest: compounds 2 and 3 (each within the scatter of the next); then compound 1.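

In this assay, among the compounds shown here, putting anilino in place of isopropoxy on a saturated chain carbon bound to a double-bonded ring carbon gives a number 99.2 percentage points lower from compound 1 to compound 3 (beyond the scatter) and is the first single-change step in this set. It shows that this one place can decide the outcome at the single dose tested: with the shared core left as it is, compound 3 gives 0%, so the core alone does not ensure inhibition in the whole organism. No measurement available here explains why the number falls with this change.

The compounds shown leave open whether the fall goes with the nitrogen or with the aromatic ring: a phenoxy group would keep the ring but link it through oxygen, while an isopropylamino group would keep the short chain but link it through nitrogen. Also open, on these data alone, is how much the isopropoxy group can change, for example to methoxy or to a longer butoxy chain, before the number in this assay moves beyond the scatter.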